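A few compounds are considered here, and "the series" means these few. Any claim that something is new, unique, unknown or untested is made for them only; others in the source may bear on it.

Measured so far in a functional assay on HepG2 cells (Homo sapiens) for inhibition, read by MTT assay, with a stated time of 72 h; on this read-out lower numbers stand for stronger inhibition and higher numbers for weaker inhibition:
compound 1, `O=c1cc(Cn2cc(CCCO)nn2)c2ccc(O)cc2o1`: > 100000 nM
compound 2, `CC(C)(C)c1cn(Cc2cc(=O)oc3cc(O)ccc23)nn1`: > 100000 nM

In this assay compound 1 gives only > 100000 nM, a limit of the assay and not a number. Compound 2 likewise gives only a limit, > 100000 nM. For the measured compounds named here, the single measured step, a step that the two limits leave unreadable from compound 1 to compound 2, is thus unreadable, as the limit of > 100000 nM in this assay, at which 2 of the 2 values shown sit, shows. Compound 3, `O=c1cc(Cn2cc(CSC(=S)N3CCOCC3)nn2)c2ccc(O)cc2o1`, differs from compound 1 by a group of 9 heavy atoms (5 carbon, 1 nitrogen, 1 oxygen, 2 sulfur; one six-membered non-aromatic ring with 2 hetero atoms) in place of a group of 3 heavy atoms (2 carbon, 1 oxygen; no ring), on a saturated chain carbon bound to an aromatic carbon. No readable measured step bears on this change, so no direction beyond the scatter is expected in this assay. Compound 3 is estimated at 150000 nM, within 30000 nM to 600000 nM. That estimate would mean a step that the limit leaves unreadable from compound 1 to compound 3.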

Compound 3, half-maximal inhibitory concentration: 99400 nM
For compound 3 the middle estimate is 1.5-fold (0.18 log units) above the measured one; measured number inside the range.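

For the compounds shown here, at the saturated chain carbon bound to an aromatic carbon, the group of 9 heavy atoms with its six-membered non-aromatic ring in place of 2-hydroxyethyl gives the only number so far in this assay, and the step reads a number no higher from compound 1 to compound 3 (the limit leaves the size open). Going by these compounds, this position therefore gives a first readable value, though the size of the change stays open and the step between the other two compounds cannot be read. The other values remain limits, not numbers: the limit of > 100000 nM in this assay, at which 2 of the 3 values shown sit.

The compounds shown leave open which part of the entering group matters. They also leave open whether a simple amine or a carboxylic acid on the same chain carbon would give a number rather than a limit.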